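The compounds below may be only part of what the source reports. "The series", "measured", "known", "first", "only" and "open" are said of these compounds alone.

Values in an ADME assay on microsomes from liver (Rattus norvegicus) for metabolic stability, read by LC-MS, using NADPH, at 37 degrees C; on this read-out higher numbers stand for a longer-lived compound and lower numbers for a shorter-lived compound:
- Compound 1 `Cc1ccccc1-c1nc(CN2CCC(C(=O)NCCCN3CCC(C)(C)CC3)CC2)c(C)o1`: > 0.5 h (a limit)
- Compound 2 `Cc1oc(-c2c(Cl)cccc2Cl)nc1CN1CCC(C(=O)NCCCN2C[C@H](C)C[C@H](C)C2)CC1`: 0.0483 h
- Compound 3 `Cc1ccccc1-c1nc(CN2CCC(C(=O)NCCCN3[C@H](C)CCC[C@@H]3C)CC2)c(C)o1`: > 0.5 h (a limit)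

Compound 3 stands at a limit, > 0.5 h, and not at a number. Compound 4 `Cc1ccccc1-c1nc(CN2CCC(C(=O)NCCN3C[C@H](C)C[C@H](C)C3)CC2)c(C)o1` carries 3,5-dimethylpiperidin-1-yl in place of (2,6-dimethylpiperidin-1-yl)methyl on a saturated chain carbon, two bonds along the chain from an amide-type nitrogen. For the measured compounds named here, the one measured step, a step that the two limits leave unreadable from compound 1 to compound 3, offers no size to carry over, and the ceiling of the data is the limit of > 0.5 h in this assay, at which 2 of the 3 values shown sit. The closest guide is compound 2, which also carries 3,5-dimethylpiperidin-1-yl but differs elsewhere from compound 4. Compound 2 stands at 0.0483 h. A shorter half-life in this assay is therefore expected, as an estimated step of an at least 5.0-fold lower number from compound 3 to compound 4 (0.69 log units; beyond the scatter). For compound 4 the estimate is 0.1 h, with an expected range of 0.03 h to 0.4 h.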

Compound 4, half-life: > 0.5 h
Compound 4: no number, only a limit; the forecaster's own chance of this, stated with the estimate: 15%; middle value at least 5.0-fold (0.69 log units) from the limit.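

Compound 1, compound 3 and compound 4 all stand at a limit, so no step among them can be read: the limit of > 0.5 h in this assay, at which 3 of the 4 values shown sit.

What the compounds shown leave open is how far the half-lives of these three compounds lie apart in this assay.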